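The source may hold more compounds than are shown below. What is called first, only, known or untested is meant among the compounds shown, and "the series" means these compounds.

Measured compounds:
- Compound 1 `CO[C@@H]1[C@H]2OC(=O)C[C@H]2O[C@@H]1[C@@H](O)c1ccccc1`: 19000 nM
- Compound 2 `O=C1C[C@H]2O[C@H](C(O)O)[C@H](O)[C@H]2O1`: 22000 nM
- Compound 3 `CO[C@@H]1[C@H]2OC(=O)C[C@H]2O[C@@H]1[C@H](O)c1ccccc1`: 25000 nM

These values come from a functional assay on HL-60 cells (Homo sapiens) for inhibition, read by MTT assay, with a stated time of 72 h; on this read-out lower numbers stand for stronger inhibition and higher numbers for weaker inhibition. Compound 3, at 25000 nM, lies within the usual scatter of both compound 1 and compound 2, so the numbers do not separate these three compounds.

Compound 4 `CO[C@@H]1[C@H]2OC(=O)C[C@H]2O[C@@H]1[C@H](OC)c1ccccc1` has not yet been measured. It differs from compound 3 by methyl in place of hydrogen on an oxygen on a saturated carbon, or hydroxy to methoxy.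

For the measured compounds named here, only one measured step connects close relatives here: a 1.3-fold higher number from compound 1 to compound 3 (0.12 log units; within the scatter). This small step reflects (the fact that compounds 1 and 3 differ only in the configuration as drawn), so it does not test the new methyl directly. Going by the values given here, with no measured example of this exact change, the best starting assumption is that the value stays near that of compound 3, with wide uncertainty.

The expected result is no shift beyond the scatter in this assay, with an estimated step of a 1.3-fold lower number from compound 3 to compound 4 (0.10 log units; within the scatter).

For compound 4, the estimated value is 20000 nM, with an expected range of 7000 nM to 55000 nM.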

Compound 4, half-maximal inhibitory concentration: 2210 nM
Compound 4: middle estimate off by 9.0-fold (0.96 log units), on the high side; measured number below the stated range.
By their numbers in this assay, from the lowest: compound 4; then compounds 1, 2 and 3 (each within the scatter of the next).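

In this assay, the change from hydroxy to methoxy gives an 11-fold lower number from compound 3 to compound 4 (1.05 log units; beyond the scatter), the only step shown that lies beyond the scatter. The oxygen on this saturated carbon is therefore a place where adding a single methyl makes a large difference to the number. The earlier compounds could not reveal this, since their numbers do not separate and the one step among them left the hydroxy in place: the fact that compounds 1 and 3 differ only in the configuration as drawn

The compounds shown leave open whether methoxy would give a similar step with the configuration drawn in compound 1, and whether the effect depends on the methyl itself or simply on replacing the hydrogen on that oxygen. They also leave open what a longer chain such as ethoxy, or an amine in place of the methoxy, would do at this position.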